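Methoxy additions and cytotoxicity in a small series

A few compounds are considered here, and "the series" means these few. Any claim that something is new, unique, unknown or untested is made for them only; others in the source may bear on it.

Compound 1, `COc1ccc(/C=C2\CCC/C(=C\c3cccc(OC)c3OC)C2=O)cc1`: in a functional assay on HT-1080 cells (Homo sapiens) for cytotoxicity, read by MTT assay, with a stated time of 72 h (on this read-out higher numbers stand for weaker inhibition and lower numbers for stronger inhibition), compound 1 gives 16300 nM.
Compound 2, `COc1ccc(/C=C2\CCC/C(=C\c3cccc(OC)c3OC)C2=O)c(OC)c1`: in this assay compound 2 gives > 20000 nM, which is a limit of the assay and not a number.
Compound 3, `COc1cc(/C=C2\CCC/C(=C\c3cccc(OC)c3OC)C2=O)cc(OC)c1`: in this assay compound 3 gives 4500 nM.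

Of the two numbers, compound 3 has the lower one, and the gap to compound 1 lies beyond the scatter. How the core of compound 1 and the core of compound 3 differ is not broken down here.

From compound 1 to compound 2 the change is methoxy in place of hydrogen on an aromatic carbon. The step is an at least 1.2-fold higher number from compound 1 to compound 2 (0.08 log units; that floor lies within the scatter); the floor rests on (the limit of > 20000 nM in this assay, at which 1 of the 3 values shown sits).

Compound 4, `COc1cccc(/C=C2\CCC/C(=C\c3cc(OC)c(OC)c(OC)c3)C2=O)c1OC`, is not yet measured. It differs from compound 3 by methoxy in place of hydrogen on an aromatic carbon. This is the same kind of change as from compound 1 to compound 2, not the same: there the entering methoxy sits ortho to a large group and meta to a methoxy group, here it sits ortho to two methoxy groups and para to a large group.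

The expected step from compound 3 to compound 4 is a 1.3-fold higher number from compound 3 to compound 4 (0.12 log units; within the scatter), set close to no change because an at least 1.2-fold higher number from compound 1 to compound 2 (0.08 log units; that floor lies within the scatter) gives only a floor that lies within the scatter. Compound 4 is expected to give 6000 nM in this assay, with an expected range from 2000 nM to 20000 nM.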

Compound 4, half-maximal inhibitory concentration: 2300 nM
Compound 4: middle estimate off by 2.6-fold (0.42 log units), on the high side, and the stated range covers the measured number.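

In this assay, methoxy in place of hydrogen on an aromatic carbon, here ortho to two methoxy groups and para to a large group, gives a 2.0-fold lower number from compound 3 to compound 4 (0.29 log units; within the scatter). On this core the change therefore stays inside the usual scatter, and neither a gain nor a loss can be claimed for it. Set beside the same kind of change on the core of compound 1, the comparison reads: the same change on two cores in this assay, an at least 1.2-fold higher number (0.08 log units; that floor lies within the scatter) from compound 1 to compound 2 and a 2.0-fold lower number (0.29 log units; within the scatter) from compound 3 to compound 4; the limit leaves it open whether they differ. From the compounds shown here alone, compound 2 stands at a limit of the assay and not at a number, so the full size of the step on that core stays unknown, and the series shows neither that the change carries over from one core to the other nor that it fails to: the limit of > 20000 nM in this assay, at which 1 of the 4 values shown sits.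

Open for now is how the same place would read with a group other than methoxy, such as a hydroxy group, an amine, a carboxylic acid or a longer alkoxy chain. Also open is whether the change would read alike on further cores, or in cells other than those of this cytotoxicity read-out, as the compounds shown cover only two pairs in one cell line.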